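This account rests on a few compounds, and the source may have more. Where it says the series, first, only, none or still open, it means among the compounds named here.

Three chalcone-like compounds sharing the same pyrazole-bearing core were tested in a functional assay on M14 cells (Homo sapiens) for cytotoxicity, read by sulforhodamine B assay, with a stated time of 48 h, tested at 100 uM; a lower number here means a stronger effect, a higher number a weaker effect of the compound at the concentration tested. Compound 1 `COc1cc(-c2cc(/C=C/C(=O)c3ccc(N)cc3)[nH]n2)cc(OC)c1OC` carries a 4-aminophenyl on the carbonyl carbon and in this assay compound 1 gives -78%. Compound 2 `COc1cc(-c2cc(/C=C/C(=O)c3ccc(Cl)c(Cl)c3)[nH]n2)cc(OC)c1OC` carries a 3,4-dichlorophenyl there, and compound 2 gives 20%. Compound 3 `COc1ccc(C(=O)/C=C/c2cc(-c3cc(OC)c(OC)c(OC)c3)n[nH]2)cc1OC` carries a 3,4-dimethoxyphenyl, and compound 3 gives -68%. Compound 3 thus stands second highest of the three numbers: the step of a number 10 percentage points higher from compound 1 to compound 3 (within the scatter) lies within the scatter, whereas the step of a number 88 percentage points lower from compound 2 to compound 3 (beyond the scatter) is a large one, as is a number 98 percentage points higher from compound 1 to compound 2 (beyond the scatter).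

Compound 4 `COc1ccc(C(=O)/C=C/c2cc(-c3cc(OC)c(OC)c(OC)c3)n[nH]2)cc1` differs from compound 3 by hydrogen in place of methoxy on an aromatic carbon. All three measured steps also alter the aryl group on the carbonyl carbon, but each swaps the whole ring; none removes a single methoxy. Within the data shown here, the only step of modest size, from compound 1 to compound 3, shows that a singly substituted phenyl and a doubly substituted one can give much the same number, so the 3,4-dimethoxyphenyl to 4-methoxyphenyl change is expected to produce at most a small step, a number 8 percentage points higher from compound 3 to compound 4 (within the scatter), in this assay. Compound 4 is therefore estimated at -60%, with a range from -90% to -15%.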

Compound 4, a percentage reported as activity, at one concentration (the size of the read-out at that concentration, not a potency): -7%
Compound 4: the middle estimate sits 53 percentage points below what was measured; measured number outside the range, above it.
By their numbers in this assay, from the lowest: compounds 1 and 3 (each within the scatter of the next); then compound 4; then compound 2.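

In this assay the result shows that this one methoxy on an aromatic carbon, ortho to a methoxy group, matters on its own: its loss gives a number 61 percentage points higher from compound 3 to compound 4 (beyond the scatter), a large step that the earlier swaps of the whole ring could not assign to any single group. The 4-methoxyphenyl also takes a place of its own among the groups on the carbonyl carbon, with a number 71 percentage points higher from compound 1 to compound 4 (beyond the scatter) on one side and a number 27 percentage points lower from compound 2 to compound 4 (beyond the scatter) on the other, so a singly substituted ring does not necessarily behave like the 4-aminophenyl of compound 1 , and it also stays apart from the 3,4-dichlorophenyl of compound 2 . Nothing available explains why removing this methoxy has so large an effect.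

The compounds shown do not tell whether a hydroxyl, an amine or an ethoxy group on that same carbon would keep the number near that of compound 3 , or whether only methoxy does so. They also leave open where an unsubstituted phenyl on the carbonyl carbon would stand relative to compound 4 .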